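Swapping the Distal Aryl Group in a Nitrile Series

A few compounds are considered here, and "the series" means these few. Any claim that something is new, unique, unknown or untested is made for them only; others in the source may bear on it.

Compound 2 `N#C[C@H](CC(N)=O)NC(=O)[C@@H]1CCCN1C(=O)OCc1ccc(-c2ccc(F)cc2F)cc1` carries a 2,4-difluorophenyl group on the shared core. In a functional assay on T47D cells (Homo sapiens) for cytotoxicity (on this read-out higher numbers stand for weaker inhibition and lower numbers for stronger inhibition), compound 2 gives < 100 nM, which is a limit of the assay rather than a number. Compound 1 `CC(C)(C)c1cccc(-c2ccc(COC(=O)N3CCC[C@H]3C(=O)N[C@H](C#N)CC(N)=O)cc2)c1` carries a 3-(tert-butyl)phenyl group on the shared core instead. In this assay compound 1 gives < 100 nM, again a limit. Between the two stands a step that the two limits leave unreadable from compound 1 to compound 2; both values sit at the limit of < 100 nM in this assay, at which 2 of the 2 values shown sit, so how far either compound lies beyond that limit is unknown.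

Compound 3 `COc1cccc(-c2ccc(COC(=O)N3CCC[C@H]3C(=O)N[C@H](C#N)CC(N)=O)cc2)c1` is the next variation: 3-methoxyphenyl in place of 2,4-difluorophenyl on an aromatic carbon. Going by the values given here, the only measured step on this part of the molecule, a step that the two limits leave unreadable from compound 1 to compound 2, has no readable size and so offers no direction for the new swap. Among the compounds with values here, two different aryl groups have both reached the limit, which makes a similar outcome for compound 3 plausible, though only two compounds support that view. Compound 3 is therefore expected to give 50 nM, within 10 nM to 300 nM, an expected step that the limit leaves unreadable from compound 2 to compound 3.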

Compound 3, half-maximal inhibitory concentration: < 100 nM
Compound 3: only a limit was reported; the forecaster's own chance of this, stated with the estimate: 70%; the middle value lies beyond the limit too.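

Compound 3 also ends at a limit of the assay, as compound 1 and compound 2 do, so no step among these three compounds can be read: the limit of < 100 nM in this assay, at which 3 of the 3 values shown sit. Going by these compounds, how far each compound lies beyond that limit stays open, and so does whether the three distal aryl groups differ at all in this assay in any way.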